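This account rests on a few compounds, and the source may have more. Where it says the series, first, only, none or still open, it means among the compounds named here.

Among the compounds with values here, compound 1 `Cc1cn2cccc(OCc3ccccc3)c2n1` is one of three compounds measured in a functional assay on the whole organism (stomach) for inhibition, with Canis familiaris (Canis lupus familiaris) as the target, at a dose of 5 mg/kg by the intravenous route; a lower number here means a weaker effect, a higher number a stronger effect of the compound at the dose given. Compound 1 gives 70%, the second highest of the three numbers. Compound 2 `Cc1nc2c(OCc3ccccc3)cccn2c1CO` gives 80%, and compound 3 `Cc1nc2c(OCc3ccccc3)cccn2c1Cl` gives 37%. Compound 4 `CCCCC(=O)OCc1c(C)nc2c(OCc3ccccc3)cccn12` has not yet been measured; it differs from compound 1 in one place: ((butylcarbonyl)oxy)methyl in place of hydrogen on an aromatic carbon. Within the data shown here, two measured steps bear on this change. The closer comparison is a number 10 percentage points higher from compound 1 to compound 2 (within the scatter), which replaces the same hydrogen and stays within the scatter. The other is a number 33 percentage points lower from compound 1 to compound 3 (beyond the scatter), a large drop with a chloro group instead. The entering group resembles hydroxymethyl far more than chloro, so a step within the scatter is expected, a number 2 percentage points higher from compound 1 to compound 4 (within the scatter). Compound 4 is therefore estimated at 72%, within a range from 50% to 90%.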

Compound 4, a percentage reported as inhibition, in the whole organism at one dose (the size of the read-out at that dose, not a potency): 96%
Compound 4: the middle estimate sits 24 percentage points below what was measured; the whole stated range lies below it.
By their numbers in this assay, from the lowest: compound 3; then compounds 1 and 2 (each within the scatter of the next); then compound 4.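

In this assay, this position on the five-membered aromatic ring accepts the much larger ((butylcarbonyl)oxy)methyl group, which gives a number 26 percentage points higher from compound 1 to compound 4 (beyond the scatter), whereas hydroxymethyl stayed within the scatter. Placing butylcarbonyl on the oxygen of hydroxymethyl gives a number 16 percentage points higher from compound 2 to compound 4 (beyond the scatter), so a hydrogen on that oxygen is not required for the effect at this dose. Exchanging chloro for the new group gives a number 59 percentage points higher from compound 3 to compound 4 (beyond the scatter).

Nothing shown explains why the number rises. On these data alone, whether a shorter acetyl group or a longer chain on that oxygen, or an amine in its place, would give a similar number remains open.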